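A few compounds are considered here, and "the series" means these few. Any claim that something is new, unique, unknown or untested is made for them only; others in the source may bear on it.

Compound 1 `Nc1cc(N)c2nc(-c3ccccc3)c(NCc3ccc(Cl)c(Cl)c3)nc2c1` gives 66100 nM in a functional assay on COLO 205 cells (Homo sapiens) for inhibition, read by sulforhodamine B assay, with a stated time of 48 h; a higher number here means that more compound is tolerated, a lower number that less compound is tolerated. Compound 2 `COc1ccc(CNc2nc3cc(N)cc(N)c3nc2-c2ccccc2)cc1OC` is reported only as a limit in this assay, < 100000 nM. Compound 3 `CCOC(=O)[C@H](CCC(=O)O)NC(=O)c1ccc(Sc2nc3cc(N)cc(N)c3nc2-c2ccccc2)cc1` likewise sits at a limit in this assay, < 100000 nM.

Compound 2 therefore stands on no number of its own, only at a limit, and the step that the limit leaves unreadable from compound 1 to compound 2 cannot be read because the limit of < 100000 nM in this assay, at which 2 of the 3 values shown sit, covers it. Compound 4 `COc1cc(CNc2nc3cc(N)cc(N)c3nc2-c2ccccc2)cc(OC)c1OC` differs from compound 2 by methoxy in place of hydrogen on an aromatic carbon. Among the measured compounds shown here, no measured step bears on this change, and the limit leaves no size to lean on. Compound 4 is expected to behave like compound 2, with the step that the limit leaves unreadable from compound 2 to compound 4 estimated to lie within the scatter. The estimate for compound 4 is 70000 nM, ranging from 30000 nM to 150000 nM.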

Compound 4, concentration lethal to 50% of the cells: < 50200 nM
Compound 4: only a limit was reported (the forecaster's own chance of this, stated with the estimate: 60%); at least 1.3-fold (0.14 log units) between middle value and limit.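

In this assay, among the compounds shown here, compound 4 is reported only as a limit (< 50200 nM) and compound 2 is also a limit, so no step from compound 2 to compound 4 can be read. The compounds shown leave open whether methoxy in place of hydrogen on an aromatic carbon shifts this read-out at all.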